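Adding One Methyl to Compound 3

The compounds below may be only part of what the source reports. "The series", "measured", "known", "first", "only" and "open" are said of these compounds alone.

In a physicochemical assay for lipophilicity (on this read-out lower numbers stand for lower lipophilicity and higher numbers for higher lipophilicity), compound 3 `Nc1ncnc2c1ncn2[C@H]1C=C[C@@H](COP2(=O)OCc3ccccc3O2)O1` reads 0.36. Compound 1 `OCC1CCC(n2cnc3ncnc(O)c32)O1` gives -1.25, a much lower number and a gap well beyond the usual scatter of repeated measurements. Compound 2 `COc1ccc2c(c1)COP(=O)(OC[C@@H]1C=C[C@H](n3cnc4c(N)ncnc43)O1)O2` has two entries rather than a single number, 0.41; 0.48 (2 entries). Compound 4 `Cc1cccc2c1OP(=O)(OC[C@@H]1C=C[C@H](n3cnc4c(N)ncnc43)O1)OC2` differs from compound 3 by having methyl in place of hydrogen on an aromatic carbon. Among the measured compounds shown here, no measured pair here shows this change on its own, so the expectation rests on the size of the change itself: a modest rise in this assay, small beside the gap separating compound 1 and compound 3. The expected change is a number 0.44 log units higher from compound 3 to compound 4 (beyond the scatter). The estimate for compound 4 is 0.8, with an expected range of 0.4 to 1.2.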

Compound 4, partition coefficient: 0.63
For compound 4 the middle estimate is 0.17 log units above the measured one; measured number inside the range.
By their numbers in this assay, from the lowest: compound 1; then compounds 3 and 4 (each within the scatter of the next).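

In this assay, methyl in place of hydrogen on an aromatic carbon gives a number 0.27 log units higher from compound 3 to compound 4 (within the scatter), the first measured view of this change at this place. On this read-out, compound 3 and compound 4 therefore cannot be ranked, and one added methyl here need not shift the number measurably. Repeat entries for a single compound also differ slightly: the several entries of compound 2 in this assay, 0.41; 0.48 (2 entries)

Going by these compounds, whether an ethyl, a chlorine atom or an amine on this same carbon would move the number beyond the scatter remains open. So does whether methyl on another carbon of this ring would behave alike.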